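A few compounds are considered here, and "the series" means these few. Any claim that something is new, unique, unknown or untested is made for them only; others in the source may bear on it.

Measured so far in a physicochemical assay for lipophilicity; on this read-out lower numbers stand for lower lipophilicity and higher numbers for higher lipophilicity: compound 1 `CC(C)CCN(CCC(C)C)c1ccc(C(=O)N2CCc3ccc(OS(N)(=O)=O)cc3C2)cc1` gives 1.93; compound 2 `CCCN(CCC)c1ccc(C(=O)N2CCc3ccc(OS(N)(=O)=O)cc3C2)cc1` gives 3.07; compound 3 `CCN(Cc1ccc(Br)cc1)c1ccc(C(=O)N2CCc3ccc(OS(N)(=O)=O)cc3C2)cc1` gives 1.93.

Compound 3 stands level with compound 1, the two together at the bottom of the three numbers, since no change at the digits printed from compound 1 to compound 3 (within the scatter); its only real distance is to compound 2, seen in a number 1.14 log units lower from compound 2 to compound 3 (beyond the scatter). Compound 4 `CCN(Cc1ccncc1)c1ccc(C(=O)N2CCc3ccc(OS(N)(=O)=O)cc3C2)cc1` differs from compound 3 in one place: pyridin-4-yl in place of 4-bromophenyl on a saturated chain carbon bound to a nitrogen on an aromatic ring. Among the compounds with values here, no measured step touches the 4-bromophenyl group itself; the two steps reaching compound 3 exchange the whole group on the aromatic nitrogen and so give only loose guidance. In this assay a downward step from compound 3 is nevertheless expected, with wide uncertainty, as a number 0.73 log units lower from compound 3 to compound 4 (beyond the scatter) expresses. For compound 4 the estimate is 1.2, ranging from 0.3 to 2.1.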

Compound 4, partition coefficient: 1.93
Compound 4: middle estimate off by 0.73 log units, on the low side; the measured number falls inside the stated range.
By their numbers in this assay, from the lowest: compounds 1, 3 and 4 (each within the scatter of the next); then compound 2.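

In this assay, within the data shown here, pyridin-4-yl in place of 4-bromophenyl gives no change at the digits printed from compound 3 to compound 4 (within the scatter), the first step that touches this group alone, and the ring with one hetero atom leaves the number level with the carbon-only ring that carries bromine. Exchanges of the whole amino group read alike: there is no change at the digits printed from compound 1 to compound 4 (within the scatter), while a number 1.14 log units lower from compound 2 to compound 4 (beyond the scatter) repeats the gap already printed for the bromine-bearing compound. Nothing at hand accounts for this level reading. Going by these compounds, whether an amine or a carboxylic acid in place of pyridin-4-yl would stay level remains open.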